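The source may hold more compounds than are shown below. What is called first, only, known or untested is meant among the compounds shown, and "the series" means these compounds.

Compound 1 `CCC(C)C(NC(=O)n1nnc2ccccc21)C(=O)NC1CCCCC1` and compound 2 `CC(C)C(NC(=O)n1nnc2ccccc21)C(=O)NC1CCCC1` share the same core and differ only in the amide substituents at either end. In a functional assay on WI-38 cells (Homo sapiens) for inhibition (on this read-out higher numbers stand for weaker inhibition and lower numbers for stronger inhibition), compound 1 gives no number but only a limit of the assay, > 100000 nM. In this assay compound 2 likewise stops at a limit, >= 100000 nM. Compound 2 therefore stands at the edge of what the assay reports, as does the other value shown the limit of > 100000 nM in this assay, at which 1 of the 2 values shown sits (the limit of >= 100000 nM in this assay, at which 1 of the 2 values shown sits), and no order between the two can be read. Compound 3 `CC(C)C(NC(=O)n1nnc2ccccc21)C(=O)NC1CCCCC1` carries cyclohexyl in place of cyclopentyl on an amide-type nitrogen, that is, cyclohexyl in place of cyclopentyl on an amide-type nitrogen. Compound 1 already carries a cyclohexyl on that amide-type nitrogen and sits at its limit. No shift beyond the scatter is expected for this step, so the change from compound 2 to compound 3 is estimated at a number no higher from compound 2 to compound 3 (the limit leaves the size open). Compound 3 is expected at 100000 nM, between 30000 nM and 300000 nM, most likely reported again only as a limit.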

Compound 3, half-maximal inhibitory concentration: >= 100000 nM
Compound 3 ended at the assay's limit (the forecaster's own chance of this, stated with the estimate: 80%); the middle value sits exactly at the limit.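

Among these compounds, compound 3, like compound 1 and compound 2, stops at a limit in this assay, so no step between compound 3 and either of the other two can be read. The compounds shown leave open whether cyclohexyl and cyclopentyl on the amide-type nitrogen differ at all in this read-out.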